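Moving the Fluorine on the Phenyl at the Core

The source may report more compounds than this note shows. Statements on the series, on what has been measured and on what is new or still open speak of the compounds shown alone.

Three compounds have been measured in an ADME assay on microsomes from liver (Homo sapiens) for metabolic stability, tested at 2.5 uM; on this read-out lower numbers stand for slow clearance and higher numbers for fast clearance:

Compound 1 `O=S(=O)(c1cc(F)cc(F)c1)c1cnc2c(F)cccc2c1-c1ccccc1F` — 0.09 mL/min
Compound 2 `O=S(=O)(c1cc(Cl)cc(Cl)c1)c1cnc2c(F)cccc2c1-c1ccccc1F` — 0.44 mL/min
Compound 3 `O=S(=O)(c1ccc(F)c(F)c1)c1cnc2c(F)cccc2c1-c1ccccc1F` — 1.39 mL/min

Compound 1 stands lowest of the three: a 4.9-fold higher number from compound 1 to compound 2 (0.69 log units; beyond the scatter) and a 15-fold higher number from compound 1 to compound 3 (1.19 log units; beyond the scatter). Between the other two, a 3.2-fold higher number from compound 2 to compound 3 (0.50 log units; beyond the scatter).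

Compound 4 `O=S(=O)(c1cc(F)cc(F)c1)c1cnc2c(F)cccc2c1-c1cccc(F)c1` differs from compound 1 in a different place than any of these steps: 3-fluorophenyl in place of 2-fluorophenyl on an aromatic carbon. All three measured steps alter the ring on the sulfonyl sulfur and leave this group untouched, so none of them bears directly on the change. With nothing to anchor a direction, the expectation for compound 4 in this assay is a step of no more than the scatter, in either direction. Compound 4 is estimated at 0.14 mL/min, within a range of 0.04 mL/min to 0.5 mL/min. That estimate means an expected 1.6-fold higher number from compound 1 to compound 4 (0.19 log units; within the scatter).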

Compound 4, intrinsic clearance in a liver preparation (reported as CLH), per the amount of preparation that the assay uses: 1.18 mL/min
Compound 4: middle estimate off by 8.4-fold (0.93 log units), on the low side; measured number above the stated range.
By their numbers in this assay, from the lowest: compound 1; then compound 2; then compounds 4 and 3 (each within the scatter of the next).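

The aromatic carbon of the shared core carrying the fluorophenyl group proves as sensitive as the ring on the sulfonyl sulfur in this assay: moving the fluorine alone, with the same atoms joined differently, gives a 13-fold higher number from compound 1 to compound 4 (1.12 log units; beyond the scatter). That step is large, as is a 15-fold higher number from compound 1 to compound 3 (1.19 log units; beyond the scatter), so a change of fluorine position counts on both rings of compound 1. No measurement at hand explains this step.

Still open, as far as these compounds go, is how an unsubstituted phenyl, a 2-chlorophenyl or a 2-methoxyphenyl would fare at this place. Also open, from the compounds shown here alone, is whether the step from 2-fluorophenyl to 3-fluorophenyl would be of similar size with the sulfonyl rings of compound 2 or compound 3.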